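Swapping the aromatic group on the ring amine of compound 1

This account rests on a few compounds, and the source may have more. Where it says the series, first, only, none or still open, it means among the compounds named here.

Three compounds share the same core and differ mainly in the aromatic group attached to a nitrogen of a six-membered non-aromatic ring. Compound 1 `O=C1c2ccccc2S(=O)(=O)N1CCCCCN1CCN(c2ccccn2)CC1` carries a pyridin-2-yl there, and in an assay on HEK293 cells for displacement of a labelled ligand from 5-hydroxytryptamine receptor 7 (Homo sapiens) (a higher number here means a weaker inhibitor, a lower number a stronger inhibitor), compound 1 gives 179 nM. Compound 2 `COc1ccccc1N1CCN(CCCCCCN2C(=O)c3ccccc3S2(=O)=O)CC1` carries a 2-methoxyphenyl and in this assay compound 2 gives 105 nM, a value within the scatter of compound 1. Compound 3 `O=C1c2ccccc2S(=O)(=O)N1CCCCCCN1CCN(c2ccc(Cl)cc2)CC1` carries a 4-chlorophenyl and compound 3 gives 487 nM, so compound 1 sits second highest of the three numbers, closest to compound 2 and furthest from compound 3.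

The new compound 4 `O=C1c2ccccc2S(=O)(=O)N1CCCCCN1CCN(c2cccc(Cl)c2Cl)CC1` is made from compound 1 by one change: 2,3-dichlorophenyl in place of pyridin-2-yl on an amine nitrogen in a ring. Going by the values given here, the only measured step that bears on it is the one from compound 2 to compound 3, a chlorophenyl in place of a methoxyphenyl on the same ring nitrogen, which gave a 4.6-fold higher number from compound 2 to compound 3 (0.67 log units; beyond the scatter). That step involved a different chlorophenyl and a different linking chain, so it is an imperfect guide, but it points toward a weaker inhibitor. A modest rise is therefore expected for compound 4, roughly a 1.7-fold higher number from compound 1 to compound 4 (0.22 log units; within the scatter), and compound 4 is estimated at 300 nM, with a likely range from 90 nM to 1000 nM.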

Compound 4, inhibition constant: 149 nM
Beside the measured number, compound 4's estimate is 2.0-fold (0.30 log units) above it; low and high end bracket the measured number.
By their numbers in this assay, from the lowest: compounds 2, 4 and 1 (each within the scatter of the next); then compound 3.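

In this assay the swap gives a 1.2-fold lower number from compound 1 to compound 4 (0.08 log units; within the scatter) and so a pyridin-2-yl and a 2,3-dichlorophenyl on this ring nitrogen cannot be told apart, even though the swap gives up the one hydrogen-bond acceptor of the pyridin-2-yl and puts 8 heavy atoms, two of them chlorine, in place of 6. The earlier pair gave a 4.6-fold higher number from compound 2 to compound 3 (0.67 log units; beyond the scatter) and could suggest that a chlorine-bearing aromatic ring here goes with a weaker inhibitor, but compound 4 goes against that reading, so the effect of chlorine at this position depends on more than its presence. Nothing measured here gives a reason why these two groups match.

Still open, as far as these compounds go, is how a plain phenyl or a pyrimidin-2-yl on this ring nitrogen would compare with the pyridin-2-yl of compound 1 on the same linking chain. Also open, from the compounds shown here alone, is whether the 2,3-dichlorophenyl would keep its standing on a longer chain, and whether a single chlorine on the phenyl ring would behave like the two in compound 4.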